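A few compounds are considered here, and "the series" means these few. Any claim that something is new, unique, unknown or untested is made for them only; others in the source may bear on it.

Of the compounds shown here, three of a shared core have been measured in a functional assay on HOS-TE85 cells (Homo sapiens) for inhibition, read by CCK-8 assay, with a stated time of 72 h; a higher number here means a weaker inhibitor, a lower number a stronger inhibitor. Compound 1 `O=C(NCCCCn1cccn1)c1cccc(C2SCC(=O)N2c2ccccn2)c1` gives 60.3 nM. Compound 3 `Cc1ccnc(N2C(=O)CSC2c2cccc(C(=O)NCCCCn3cccn3)c2)c1` gives 19.6 nM. Among the compounds with values here, the only single-point step measured so far is a 3.1-fold lower number from compound 1 to compound 3 (0.49 log units; beyond the scatter), a change on an aromatic carbon far from the ring nitrogen.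

Compound 2 `COc1ccc(OC)c(N2C(=O)CSC2c2cccc(C(=O)NCCCCc3ccccc3)c2)c1` stands apart from the other two: in this assay compound 2 gives only > 1000 nM, which is a limit of the assay and not a number. So compound 2 sits at the limit of > 1000 nM in this assay, at which 1 of the 3 values shown sits, and its true value is not known.

Compound 4 `COc1c(F)cccc1N1C(=O)CSC1c1cccc(C(=O)NCCCCc2ccccc2)c1` is not yet measured. It differs from compound 2 in one place: 3-fluoro-2-methoxyphenyl in place of 2,5-dimethoxyphenyl on an amide-type nitrogen in a ring. Within the data shown here, no measured step concerns this part of the molecule, so the step from compound 1 to compound 3 does not bear on it, and its size gives no guide. With compound 2 known only as a limit, there is no number to build from, only the expectation that compound 4 will stay in the weak range unless the change on the ring nitrogen is large in effect.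

Compound 4 is therefore estimated at 1500 nM, with a range from 300 nM to 6000 nM, which means an expected step that the limit leaves unreadable from compound 2 to compound 4.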

Compound 4, half-maximal inhibitory concentration: 26.2 nM
Compound 4: the middle estimate sits 57-fold (1.76 log units) above what was measured; measured number outside the range, below it.
By their numbers in this assay, from the lowest: compounds 3 and 4 (each within the scatter of the next); then compound 1. At a limit, above all of these: compound 2.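

In this assay, within the data shown here, placing 3-fluoro-2-methoxyphenyl instead of 2,5-dimethoxyphenyl on the amide-type nitrogen of the five-membered ring gives an at least 38-fold lower number from compound 2 to compound 4 (1.58 log units; beyond the scatter), so this position, which no earlier step touched, can on its own carry a large change in the number. As far as these compounds go, compound 2 gives > 1000 nM, which is a limit of the assay and not a number, so the full size of this step stays unknown. The swap also alters two things at once, since the entering group holds one oxygen and one fluorine where the leaving group holds two oxygens, and a single step cannot show which of these alterations matters.

A 2-methoxyphenyl group with nothing further on its ring would separate the loss of the second methoxy from the gain of the fluorine, and a 3-chloro-2-methoxyphenyl group would show whether fluorine itself is needed. From the compounds shown here alone, it also remains open whether 3-fluoro-2-methoxyphenyl would lower the number to a similar degree on the core of compound 1, with its pyridine-bearing nitrogen replaced.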